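The source may report more compounds than this note shows. Statements on the series, on what has been measured and on what is new or still open speak of the compounds shown alone.

Measured compounds:
Compound 1 `COc1cc2c(Oc3ccc(NC(=O)c4nnn(-c5ccc(F)cc5)c4C(F)(F)F)cc3F)ccnc2cc1OCCCN1CCC(C)CC1` gives 190 nM in a functional assay on NCI-H460 cells (Homo sapiens) for cytotoxicity, read by MTT assay, with a stated time of 72 h; on this read-out lower numbers stand for stronger inhibition and higher numbers for weaker inhibition.
Compound 2 `COc1cc2c(Oc3ccc(NC(=O)c4nnn(-c5ccc(C)cc5)c4C(F)(F)F)cc3F)ccnc2cc1OCCCN1CCC(C)CC1` gives 1250 nM in this assay.

Among the compounds with values here, compound 2 stands with the highest of the two numbers seen so far in this assay; its nearest neighbour is compound 1, and the step of a 6.6-fold higher number from compound 1 to compound 2 (0.82 log units; beyond the scatter) is the only measured step in this set.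

Compound 3 `COc1cc2c(Oc3ccc(NC(=O)c4nnn(-c5ccccc5C(F)(F)F)c4C(F)(F)F)cc3F)ccnc2cc1OCCCN1CCC(C)CC1` has not been measured. It differs from compound 2 by 2-(trifluoromethyl)phenyl in place of 4-methylphenyl on an aromatic nitrogen. Within the data shown here, the one measured step, a 6.6-fold higher number from compound 1 to compound 2 (0.82 log units; beyond the scatter), bears on the same aryl group attached to the aromatic nitrogen, but it swaps fluoro for methyl in one place, whereas compound 3 carries a trifluoromethyl group in another place on that ring, so the measured step informs the expectation only loosely. Taking compound 2 at 1250 nM as the starting point, compound 3 is estimated at 450 nM with a range from 120 nM to 1700 nM. The expected step of a 2.8-fold lower number from compound 2 to compound 3 (0.44 log units; beyond the scatter) therefore points towards a lower number than that of compound 2, but the range is wide and the step may also fall within the scatter.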

Compound 3, half-maximal inhibitory concentration: 250 nM
For compound 3 the middle estimate is 1.8-fold (0.26 log units) above the measured one; low and high end bracket the measured number.
By their numbers in this assay, from the lowest: compounds 1 and 3 (each within the scatter of the next); then compound 2.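

Replacing 4-methylphenyl with 2-(trifluoromethyl)phenyl on the aromatic nitrogen gives a 5.0-fold lower number from compound 2 to compound 3 (0.70 log units; beyond the scatter) in this assay, so changes to the aryl group at this position have now moved the number in both directions, whereas the earlier pair showed only a rise. Set against 4-fluorophenyl, the same group gives a 1.3-fold higher number from compound 1 to compound 3 (0.12 log units; within the scatter), so compound 1 and compound 3 read alike despite carrying different substituents on that aryl group, and among the three compounds only compound 2, with its 4-methylphenyl, stands apart. No measurement offered here accounts for either step, and the reason for this pattern remains unknown.

Going by these compounds, whether the trifluoromethyl group itself or its place on the ring separates compound 3 from compound 2 stays open, as these two compounds differ in both at once. On these data alone, how a plain phenyl, or a methoxy or nitrile group on that phenyl, would read in this assay also stays open.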